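The compounds below may be only part of what the source reports. "The series", "measured", "known", "first", "only" and "open" are said of these compounds alone.

Compound 1 `CCC1(Cc2ccccc2)OS(=O)(=O)C=C1OCC#N` and compound 2 `CCC1(Cc2ccccc2)OS(=O)(=O)C=C1OCC1CCCCC1` share one core and differ at a single site. In an ADME assay on HEL cells (Homo sapiens) for cytotoxicity, with a stated time of 3 days (a lower number here means that less compound is tolerated, a higher number that more compound is tolerated), compound 1 gives only a limit, > 400000 nM. In this assay compound 2 likewise gives a limit, >= 200000 nM. Among the compounds with values here, the sole measured step, a step that the two limits leave unreadable from compound 1 to compound 2, rests on the limit of > 400000 nM in this assay, at which 1 of the 2 values shown sits, and (the limit of >= 200000 nM in this assay, at which 1 of the 2 values shown sits), so compound 2 stands at a limit, not a finished number. Compound 3 `CCC1(Cc2ccccc2)OS(=O)(=O)C=C1OCc1cccc(Cl)c1` carries 3-chlorophenyl in place of cyclohexyl on a saturated chain carbon bound to an oxygen on an unsaturated carbon. Within the data shown here, no measured step reads on this change, so no step beyond the scatter is expected in this assay; the estimated step is a number no higher from compound 2 to compound 3 (the limit leaves the size open). Compound 3 is expected at 200000 nM, between 50000 nM and 400000 nM.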

Compound 3, minimum cytotoxic concentration: >= 20000 nM
Compound 3: a limit, no number; the forecaster's own chance of this, stated with the estimate: 70%; the middle value lies beyond the limit too.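

In this assay compound 3 gives only a limit (>= 20000 nM). No new step can be read among compound 1, compound 2 and compound 3. The compounds shown leave open how far apart these three actually stand.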